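A few compounds are considered here, and "the series" means these few. Any claim that something is new, unique, unknown or untested is made for them only; others in the source may bear on it.

Measured compounds in a functional assay on MCF7 cells (Homo sapiens) for cytotoxicity, read by trypan blue exclusion, with a stated time of 48 h; on this read-out higher numbers stand for weaker inhibition and lower numbers for stronger inhibition:
Compound 1, `Cc1ccc(-c2csc(NC(=O)COc3ccccc3C)n2)cc1`, gives 53200 nM.
Compound 2, `Cc1ccccc1OCC(=O)Nc1nc(-c2ccc(Br)cc2)cs1`, gives 39700 nM.
Compound 3, `Cc1ccccc1OCC(=O)Nc1nc(-c2ccc(Cl)cc2)cs1`, gives 62800 nM.

Compound 3 holds the highest of the three numbers, but its gaps to the others are small: a 1.2-fold higher number from compound 1 to compound 3 (0.07 log units; within the scatter) and a 1.6-fold higher number from compound 2 to compound 3 (0.20 log units; within the scatter), so nothing separates it from compound 1 or compound 2 beyond the scatter. The three measured steps all concern the substituent on the aryl ring attached to the shared core: a 1.3-fold lower number from compound 1 to compound 2 (0.13 log units; within the scatter), a 1.2-fold higher number from compound 1 to compound 3 (0.07 log units; within the scatter) and a 1.6-fold higher number from compound 2 to compound 3 (0.20 log units; within the scatter), and none of them moves the number beyond the scatter.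

Compound 4, `Cc1ccc(OCC(=O)Nc2nc(-c3ccc(Cl)cc3)cs2)cc1`, differs from compound 3 elsewhere: 4-methylphenyl in place of 2-methylphenyl on an oxygen on a saturated carbon. Among the measured compounds shown here, no measured step touches this part of the molecule, so there is no direct precedent for it. For the measured compounds named here, what the series does show is that the one change explored so far left the read-out flat across compounds 1, 2 and 3. On that basis compound 4 is expected to stay close to compound 3, with a 1.0-fold lower number from compound 3 to compound 4 (0.02 log units; within the scatter) as the estimated step, and no change beyond the scatter is foreseen. Compound 4 is estimated at 60000 nM, within a range from 20000 nM to 180000 nM.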

Compound 4, half-maximal inhibitory concentration: 48800 nM
The estimate for compound 4 lay 1.2-fold (0.09 log units) above the measured number; low and high end bracket the measured number.
By their numbers in this assay, from the lowest: compounds 2, 4, 1 and 3 (each within the scatter of the next).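

Compound 4 gives the only reading shown for the part of the molecule that compounds 1, 2 and 3 share unchanged, the aryl group on an oxygen on a saturated carbon. In this assay, 4-methylphenyl in place of 2-methylphenyl gives a 1.3-fold lower number from compound 3 to compound 4 (0.11 log units; within the scatter), so this exchange of two groups with the same atoms, also readable as 2-methylphenoxy to 4-methylphenoxy, leaves the read-out as flat as the three substituent steps on the aryl ring attached to the shared core did. Nothing among the data shown offers an explanation for this flat result.

Because only these two placements of the methyl group are shown, the compounds leave open whether the read-out at this position would respond to a plain phenyl, or to a methoxy, chloro, amine or carboxylic acid group on that ring. They also leave open whether a longer chain in place of the saturated carbon, or a change at the amide hydrogen, would move the read-out beyond the scatter in a way that the changes seen here do not.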